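The source may report more compounds than this note shows. Statements on the series, on what has been measured and on what is new or still open speak of the compounds shown alone.

Of the compounds shown here, three of one shared core have been tested in a functional assay on A549 cells (Homo sapiens) for antiproliferative activity, read by MTT assay; a lower number here means a stronger inhibitor, a higher number a weaker inhibitor. Compound 1, `COc1ccc(-c2ccnc(Nc3ccc(Cl)cc3Cl)n2)cc1`, gives 7330 nM. Compound 2, `O=[N+]([O-])c1ccc(Nc2nccc(-c3ccc(F)cc3)n2)cc1`, gives 84000 nM, and compound 3, `COc1cccc(Nc2nccc(-c3ccc(Br)cc3)n2)c1`, gives 82700 nM. Compound 2 holds the highest number of the three. Its value and that of compound 3 lie within the usual scatter of each other, so nothing separates them. Compound 1, by contrast, gives a number far below that of compound 2, a gap well beyond the scatter.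

The next compound to be measured is compound 4, `COc1ccc(-c2ccnc(Nc3ccc([N+](=O)[O-])cc3)n2)cc1`. It differs from compound 2 in one place: methoxy in place of fluoro on an aromatic carbon. Put simply, a methoxy group takes the place of a fluorine on an aromatic carbon of a six-membered aromatic ring of carbon only.

Within the data shown here, no measured pair in this set shows this exact change alone, so the expectation is loose. Compound 1 also carries a methoxy group on the same kind of ring and gives 7330 nM, but it differs from compound 4 in another place too. The step is therefore expected to be a modest drop in number, a 2.4-fold lower number from compound 2 to compound 4 (0.38 log units; beyond the scatter). Compound 4 is estimated at 35000 nM, with a range from 9000 nM to 120000 nM.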

Compound 4, half-maximal inhibitory concentration: 2730 nM
Beside the measured number, compound 4's estimate is 13-fold (1.11 log units) above it, and the stated range ends above it.
By their numbers in this assay, from the lowest: compound 4; then compound 1; then compounds 3 and 2 (each within the scatter of the next).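

In this assay, among these compounds, the change from fluoro to methoxy on an aromatic carbon, para to a large group, gives a 31-fold lower number from compound 2 to compound 4 (1.49 log units; beyond the scatter) and is the first step in this set in which only one place differs. It shows that this position is not indifferent to what sits on it: going from 4-fluorophenyl to 4-methoxyphenyl, with the rest of the molecule unchanged, moves the number far beyond the usual scatter of repeated measurements. Nothing shown here explains why the swap of these two groups has so large an effect.

Going by these compounds, whether the same swap would give a similar step on a compound with a different group on the other aromatic ring stays open, since compound 1 has no fluoro partner here and compound 3 differs from the others in more than one place. Also open, on these data alone, is how this position would respond to other groups, such as a hydroxyl, an ethoxy group, an amine or a longer chain, so a single step cannot yet show a trend across substituents.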